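The compounds below may be only part of what the source reports. "The series", "measured", "known", "first", "only" and "open" are said of these compounds alone.

Measured compounds:
compound 1 `COc1cc(C(=O)c2sc3ccccc3c2-c2ccc(Cl)cc2)cc(OC)c1OC`, 3300 nM
compound 2 `COc1ccc(-c2c(C(=O)c3cc(OC)c(OC)c(OC)c3)sc3ccccc23)c(OC)c1`, 4600 nM
compound 3 `CCOc1ccc(-c2c(C(=O)c3cc(OC)c(OC)c(OC)c3)sc3ccccc23)cc1`, 3500 nM

In a functional assay on HL-60 cells (Homo sapiens) for antiproliferative activity, read by MTT assay, with a stated time of 72 h (on this read-out higher numbers stand for weaker inhibition and lower numbers for stronger inhibition), compound 1 gives the lowest of the three numbers, but its neighbours sit close: the change of a 1.4-fold higher number from compound 1 to compound 2 (0.14 log units; within the scatter) and the change of a 1.1-fold higher number from compound 1 to compound 3 (0.03 log units; within the scatter) are both within the scatter, and so is the change of a 1.3-fold lower number from compound 2 to compound 3 (0.12 log units; within the scatter). On these numbers compound 1 cannot be told apart from compound 2 or compound 3.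

Compound 4 `COc1cc(C(=O)c2sc3ccccc3c2Nc2ccc(Cl)cc2)cc(OC)c1OC` has not yet been measured in this assay. It differs from compound 1 in one place: (4-chlorophenyl)amino in place of 4-chlorophenyl on an aromatic carbon.

Going by the values given here, none of the measured steps bears directly on this change. The three steps all swap one aryl group for another on the same carbon of the shared core, and all stay within the scatter; none of them inserts a (4-chlorophenyl)amino group between the core and the ring. Among the compounds with values here, the data therefore give no direction for the step, and the estimate for compound 4 leans on the unchanged rest of the molecule, with a wide range to cover the lack of precedent.

Compound 4 is expected to give about 2500 nM in this assay, somewhere between 500 nM and 12000 nM, which means an expected step of a 1.3-fold lower number from compound 1 to compound 4 (0.12 log units; within the scatter).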

Compound 4, half-maximal inhibitory concentration: 5400 nM
Compound 4: middle estimate off by 2.2-fold (0.33 log units), on the low side; the measured number falls inside the stated range.
By their numbers in this assay, from the lowest: compounds 1, 3, 2 and 4 (each within the scatter of the next).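

In this assay, the swap of 4-chlorophenyl for (4-chlorophenyl)amino on this aromatic carbon of the five-membered ring adds a hydrogen-bond donor and a hydrogen-bond acceptor to the group, and the result is a 1.6-fold higher number from compound 1 to compound 4 (0.21 log units; within the scatter). The earlier compounds shown here varied only the directly attached aryl group, and the amino-linked group now stays just as close to them, with a 1.5-fold higher number from compound 3 to compound 4 (0.19 log units; within the scatter) and a 1.2-fold higher number from compound 2 to compound 4 (0.07 log units; within the scatter), so all four compounds sit together at this position and the added nitrogen brings no step beyond the scatter. No measurement offered here explains why these numbers stay so close.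

The compounds shown leave open whether another link at this carbon, such as a methylene, an ether oxygen or a methylamino group, would separate from the scatter, and whether the amino link behaves the same way when it carries 4-ethoxyphenyl or 2,4-dimethoxyphenyl instead of 4-chlorophenyl. They also leave open what a plain amine or a carboxylic acid on this carbon, with no aryl ring at all, would give on the shared core.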